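Swapping the chain-end ring while keeping the phenyl

This account rests on a few compounds, and the source may have more. Where it says the series, first, only, none or still open, it means among the compounds named here.

Among the compounds with values here, compound 1 `Cn1cc(C2=C(c3nn(CCCn4ccnc4)c4ncccc34)C(=O)N(c3ccccc3)C2=O)c2ccccc21` is the only compound of this group with a numerical result: in a functional assay on A549 cells (Homo sapiens) for antiproliferative activity, read by MTT assay, with a stated time of 48 h (on this read-out lower numbers stand for stronger inhibition and higher numbers for weaker inhibition), compound 1 gives 1560 nM. Compound 2 `Cn1cc(C2=C(c3nn(CCCn4ccnc4)c4ncccc34)C(=O)NC2=O)c2ccccc21` lacks the phenyl on the amide-type nitrogen in the ring, and in this assay compound 2 reaches only the limit > 100000 nM. Compound 3 `Cn1cc(C2=C(c3nn(CCCN4CCCCC4)c4ncccc34)C(=O)NC2=O)c2ccccc21` carries a piperidin-1-yl at the end of the chain, and in this assay compound 3 also reaches only the limit > 100000 nM. The step of an at least 64-fold higher number from compound 1 to compound 2 (1.80 log units; beyond the scatter) shows how much the phenyl matters. The step that the two limits leave unreadable from compound 2 to compound 3 cannot be sized, since both compounds sit at the limit of > 100000 nM in this assay, at which 2 of the 3 values shown sit.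

Compound 4 `Cn1cc(C2=C(c3nn(CCCn4cncn4)c4ncccc34)C(=O)N(c3ccccc3)C2=O)c2ccccc21` keeps the phenyl of compound 1 and changes only the ring at the end of the chain: 1H-1,2,4-triazol-1-yl in place of 1H-imidazol-1-yl on a saturated chain carbon, three bonds along the chain from an aromatic nitrogen. Within the data shown here, no measured step reads directly on this change; the closest one, from compound 2 to compound 3, is unreadable, so the expectation rests on compound 1 alone and on the modest size of the change. Compound 4 is therefore expected to stay close to compound 1, with the step of a 1.3-fold higher number from compound 1 to compound 4 (0.11 log units; within the scatter) expected to lie within the usual scatter. The estimate for compound 4 in this assay is 2000 nM, within a range of 700 nM to 6000 nM.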

Compound 4, half-maximal inhibitory concentration: > 100000 nM
Compound 4: no number, only a limit; the forecaster's own chance of this, stated with the estimate: 10%; middle value at least 50-fold (1.69 log units) away from the limit.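

In this assay, the exchange of 1H-imidazol-1-yl for 1H-1,2,4-triazol-1-yl on a saturated chain carbon, three bonds along the chain from an aromatic nitrogen, gives an at least 64-fold higher number from compound 1 to compound 4 (1.80 log units; beyond the scatter). Within the data shown here, the earlier compounds could not show this, since the only step at the chain end, from compound 2 to compound 3, cannot be read; now the chain-end ring is seen to matter, and keeping the phenyl on the amide-type nitrogen does not by itself preserve a measurable result, even though the two rings differ only by one ring carbon in compound 1 becoming a ring nitrogen in compound 4. The result for compound 4 is a limit and not a number, so the true size of the step stays unknown, and compound 4 joins the other compounds there: the limit of > 100000 nM in this assay, at which 3 of the 4 values shown sit.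

On these data alone, compound 1 remains the only numerical result, so it stays open whether any other ring at this chain end, such as 1H-pyrazol-1-yl, or an amine such as piperidin-1-yl alongside the phenyl, would give a number. As far as these compounds go, it is equally open whether a longer chain carrying 1H-imidazol-1-yl would keep, improve or lose the result of compound 1.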